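The source may report more compounds than this note shows. Statements on the series, on what has been measured and on what is new or still open speak of the compounds shown alone.

Measured so far:
compound 1, `Cc1ccc(Cn2cc(COc3ccc4c(=O)ccoc4c3)nn2)cc1`, in a functional assay on A549 cells (Homo sapiens) for cytotoxicity, read by MTT assay, with a stated time of 48 h; on this read-out lower numbers stand for stronger inhibition and higher numbers for weaker inhibition: 50700 nM.
compound 2, `N#Cc1ccc(Cn2cc(COc3ccc4c(=O)ccoc4c3)nn2)cc1`, in this assay: > 100000 nM, which is a limit of the assay rather than a number.

Compound 2 thus stands at the limit of > 100000 nM in this assay, at which 1 of the 2 values shown sits. Compound 3, `COc1ccc(Cn2cc(COc3ccc4c(=O)ccoc4c3)nn2)cc1`, differs from compound 2 by methoxy in place of cyano on an aromatic carbon. Within the data shown here, the only measured step bearing on this position, an at least 1.9-fold higher number from compound 1 to compound 2 (0.29 log units; that floor lies within the scatter), has a floor inside the scatter, so it gives no direction. Compound 3 is therefore expected to fall close to the measured values, with an at least 1.4-fold lower number from compound 2 to compound 3 (0.15 log units; that floor lies within the scatter) as the estimated step. The estimate for compound 3 in this assay is 70000 nM, within 25000 nM to 200000 nM.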

Compound 3, half-maximal inhibitory concentration: 16500 nM
The estimate for compound 3 lay 4.2-fold (0.63 log units) above the measured number; the measured number lies below the stated range.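

In this assay, the group on this aromatic carbon, para to a large group, now makes a readable difference: methoxy in place of cyano gives an at least 6.0-fold lower number from compound 2 to compound 3 (0.78 log units; beyond the scatter), and methoxy in place of methyl gives a 3.1-fold lower number from compound 1 to compound 3 (0.49 log units; beyond the scatter). Both steps lie beyond the scatter, whereas the earlier step at this position gave no direction. Compound 2 gives only a limit, so the step from it is a floor and not a size: the limit of > 100000 nM in this assay, at which 1 of the 3 values shown sits.

The compounds shown leave open how an amine, a hydroxyl or a longer alkoxy chain on this carbon would compare with methoxy. They also leave open whether methoxy would give the same result elsewhere on the ring.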